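The source may report more compounds than this note shows. Statements on the series, on what has been measured and on what is new or still open speak of the compounds shown alone.

Of the compounds shown here, three have been measured in an ADME assay on Vero cells (Chlorocebus sabaeus) for cytotoxicity, read by MTT assay, with a stated time of 72 h; a lower number here means that less compound is tolerated, a higher number that more compound is tolerated.

Compound 1 `COC(=O)c1cc(-c2cccc(NC(=O)c3ccc(/C=C/C(=O)c4cccc(C(F)(F)F)c4)cc3)c2)on1` gives > 20 ug/mL in this assay, which is a limit rather than a number.
Compound 2 `COC(=O)c1cc(-c2cccc(NC(=O)c3ccc(/C=C/C(=O)c4ccc(C)cc4)cc3)c2)on1` gives > 80 ug/mL in this assay, likewise a limit.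
Compound 3 `COC(=O)c1cc(-c2cccc(NC(=O)c3ccc(/C=C/C(=O)c4ccc(C)c([N+](=O)[O-])c4)cc3)c2)on1` gives > 80 ug/mL in this assay, again a limit.

Compound 3 therefore stands at the limit where compound 2 also sits (the limit of > 80 ug/mL in this assay, at which 2 of the 3 values shown sit), while compound 1 sits at a different limit (the limit of > 20 ug/mL in this assay, at which 1 of the 3 values shown sits). None of the three measured steps can be read: a step that the two limits leave unreadable from compound 1 to compound 2, a step that the two limits leave unreadable from compound 1 to compound 3 and a step that the two limits leave unreadable from compound 2 to compound 3 are all left without a size by the two limits.

Compound 4 `COC(=O)c1cc(-c2cccc(NC(=O)c3ccc(/C=C/C(=O)c4ccc(Cl)cc4Cl)cc3)c2)on1` has not yet been measured. It differs from compound 3 in one place: 2,4-dichlorophenyl in place of 4-methyl-3-nitrophenyl on a carbonyl carbon. Two of the unreadable steps also exchange the group on the carbonyl carbon, and both returned only limits, so the evidence bearing on this change says no more than that every variation of that group so far was tolerated up to a limit. Compound 4 is therefore expected to give a value in this assay near the limit of compound 3, with an at least 1.1-fold lower number from compound 3 to compound 4 (0.05 log units; that floor lies within the scatter) expected to stay within the scatter. Compound 4 is estimated to give 70 ug/mL, between 25 ug/mL and 120 ug/mL.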

Compound 4, half-maximal cytotoxic concentration: > 40 ug/mL
Compound 4 was reported as a limit (the forecaster's own chance of this, stated with the estimate: 65%); the middle value does not contradict the limit.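

In this assay compound 4 gives > 40 ug/mL, which is again a limit, and its steps to compound 1, compound 2 and compound 3 cannot be read. The compounds shown leave open the concentration at which any of the four reaches half-maximal cytotoxicity, and whether exchanging the group on the carbonyl carbon changes it at all.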